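Measured Values So Far and an Untested Ring Swap

This account rests on a few compounds, and the source may have more. Where it says the series, first, only, none or still open, it means among the compounds named here.

Compound 1 `COc1cc(OC)c2c(=O)cc(-c3ccc(OCCBr)cc3)oc2c1` — "not active" (no number reported)
Compound 2 `COc1cc(OC)c2c(=O)cc(-c3ccc(OCCF)cc3)oc2c1` — "not active" (no number reported)
Compound 3 `COc1cc(OC)c2c(=O)cc(-c3ccc(OCCN4CCCC4=O)cc3)oc2c1` — 14%

All three compounds share one core and differ only in the group attached through an oxygen on the aromatic ring. They were tested in a functional assay (Homo sapiens) for antiproliferative activity, read by resazurin assay, with a stated time of 48 h, tested at 10 uM; a higher number here means a stronger effect of the compound at the concentration tested, a lower number a weaker effect. In this assay compound 1 is recorded as "not active" (no number reported). Compound 2 is recorded as "not active" (no number reported). Compound 3 is the only one of the three for which a number is given; in this assay compound 3 shows 14%, a small effect at the concentration tested. Within the data shown here, no two measured compounds differ in a single place with numbers on both sides. Among the measured compounds shown here, no measured step therefore exists to show how a change at this position shifts the read-out.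

Compound 4 `COc1cc(OC)c2c(=O)cc(-c3ccc(OC4CCNCC4)cc3)oc2c1` has not yet been measured. Compared with compound 3 the change is piperidin-4-yl in place of 2-(2-oxopyrrolidin-1-yl)ethyl on an oxygen on an aromatic ring. For the measured compounds named here, with only one number known and two entries without a number, there is no basis for expecting a large move in either direction. The step from compound 3 to compound 4 is estimated to be a number 1 percentage points higher from compound 3 to compound 4 (within the scatter), within the usual scatter of this assay. Compound 4 is therefore expected to give about 15% in this assay, with a range from 0% to 40%.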

Compound 4, a percentage reported as inhibition, at one concentration (the size of the read-out at that concentration, not a potency): 21%
Compound 4: middle estimate off by 6 percentage points, on the low side; the range from low to high includes it.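

In this assay, among these compounds, exchanging 2-(2-oxopyrrolidin-1-yl)ethyl for piperidin-4-yl on the oxygen gives the first step at this position with numbers on both sides: a number 7 percentage points higher from compound 3 to compound 4 (within the scatter). The two groups differ in several ways, since a five-membered ring and a double bond outside aromatic rings leave while a six-membered ring and a hydrogen-bond donor enter, yet this assay cannot tell compound 3 and compound 4 apart at the concentration tested. Nothing available here accounts for this outcome.

Compound 1 and compound 2 carry no number, so steps from them to the other compounds cannot be read, and the two bare chain ends, bromoethyl and fluoroethyl, cannot be placed on the same scale as the ring-bearing groups. The compounds shown leave open whether any group on this oxygen can give a clearly larger effect, such as a carboxylic acid on a longer chain or an open-chain amine, and whether a methyl group on the piperidine nitrogen would make any difference.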